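The source may hold more compounds than are shown below. What is called first, only, known or untested is meant among the compounds shown, and "the series" means these compounds.

Measured compounds:
compound 1, `Cc1ccc(NC(=O)Nc2ccc(-c3nc(NCCCN(C)C)c4sc(Cl)c(Cl)c4n3)cc2)cc1`: 3700 nM
compound 2, `CCN(CC)CCCNc1nc(-c2ccc(NC(=O)Nc3ccc(Cl)cc3)cc2)nc2c(Cl)c(Cl)sc12`: 720 nM

In a functional assay on MKN-45 cells (Homo sapiens) for cytotoxicity, read by MTT assay, with a stated time of 72 h (a lower number here means a stronger inhibitor, a higher number a weaker inhibitor), compound 2 gives 720 nM, the lower of the two numbers. For the measured compounds named here, compound 1 gives 3700 nM in this assay, a gap that lies beyond the usual scatter; the two compounds differ in more than one place, so no single step can be drawn between them.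

Compound 3, `CCN(CC)CCCNc1nc(-c2ccc(NC(=O)Nc3ccc(C)cc3)cc2)nc2c(Cl)c(Cl)sc12`, has not yet been measured. It differs from compound 2 in one place: methyl in place of chloro on an aromatic carbon. The same methyl-bearing phenyl ring occurs in compound 1, whose value in this assay is the higher of the two, though compound 1 also carries a different amine chain.

Compound 3 is expected to land somewhat above compound 2, with a step of a 2.5-fold higher number from compound 2 to compound 3 (0.40 log units; beyond the scatter) toward a weaker inhibitor. Compound 3 is estimated at 1800 nM in this assay, within a range of 700 nM to 4500 nM.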

Compound 3, half-maximal inhibitory concentration: 3320 nM
For compound 3 the middle estimate is 1.8-fold (0.27 log units) below the measured one, and the stated range covers the measured number.
By their numbers in this assay, from the lowest: compound 2; then compounds 3 and 1 (each within the scatter of the next).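

In this assay, going from 4-chlorophenyl to 4-methylphenyl gives a 4.6-fold higher number from compound 2 to compound 3 (0.66 log units; beyond the scatter), so this single swap on the outer ring moves the number beyond the scatter, and chloro gives the lower number of the two. Changing the end of the amine chain gives a 1.1-fold lower number from compound 1 to compound 3 (0.05 log units; within the scatter), so with the 4-methylphenyl group in place, diethylamino and dimethylamino cannot be told apart. No measurement shown offers a reason for the step on the ring.

The compounds shown leave open whether chloro would also give the lower number with dimethylamino at the chain end. They also leave open how fluoro, methoxy or a plain hydrogen would read at this ring position, and how a cyclic amine such as piperidine would read at the chain end.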